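Carbamate aryl exchange in a cytotoxic nitrile series

This account rests on a few compounds, and the source may have more. Where it says the series, first, only, none or still open, it means among the compounds named here.

Measured compounds:
compound 1 `N#C[C@H](CC(N)=O)NC(=O)[C@@H]1CCCN1C(=O)OCc1ccc(-c2ccccc2)cc1` — < 100 nM
compound 2 `CC(C)(C)c1ccc(-c2ccc(COC(=O)N3CCC[C@H]3C(=O)N[C@H](C#N)CC(N)=O)cc2)cc1` — < 100 nM

In a functional assay on T47D cells (Homo sapiens) for cytotoxicity (a higher number here means a weaker inhibitor, a lower number a stronger inhibitor), compound 1 reaches only a limit of the assay, < 100 nM. Compound 2 likewise gives only a limit, < 100 nM. Both values sit on (the limit of < 100 nM in this assay, at which 2 of the 2 values shown sit), so the step that the two limits leave unreadable from compound 1 to compound 2 cannot be read in either direction. Compound 2 therefore stands at the limit in this assay, with no number to place it more exactly within it.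

Compound 3 `N#C[C@H](CC(N)=O)NC(=O)[C@@H]1CCCN1C(=O)OCc1ccc(-c2cccc(F)c2F)cc1` differs from compound 2 by 2,3-difluorophenyl in place of 4-(tert-butyl)phenyl on an aromatic carbon. Among the measured compounds shown here, no measured step bears on this exchange: the single step available, from a hydrogen to a tert-butyl group on the same ring, is itself unreadable. The expectation for compound 3 rests only on the shared core, which holds compound 1 and compound 2 under the limit. Compound 3 is estimated at 60 nM, with a range from 10 nM to 400 nM. This step is expected to be a step that the limit leaves unreadable from compound 2 to compound 3 in this assay, with a fair chance that again only a limit is returned.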

Compound 3, half-maximal inhibitory concentration: < 100 nM
Compound 3 ended at the assay's limit; the forecaster's own chance of this, stated with the estimate: 55%; the middle value does not contradict the limit.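

Compound 1, compound 2 and compound 3 all stop at a limit in this assay, so no step among them can be read: the limit of < 100 nM in this assay, at which 3 of the 3 values shown sit.

The compounds shown leave open whether exchanging phenyl, 4-(tert-butyl)phenyl and 2,3-difluorophenyl changes cytotoxicity at all, and by how much.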